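A few compounds are considered here, and "the series" means these few. Any claim that something is new, unique, unknown or untested is made for them only; others in the source may bear on it.

Compound 2 `COc1cccc(OC)c1C(=O)N1C[C@@H]2CN(c3nc4ccc(Cl)cc4s3)C[C@@H]2C1` is the weaker of the two measured compounds: in an assay on isolated protein for binding affinity to Orexin/Hypocretin receptor type 1 (Homo sapiens) (a higher number here means a weaker inhibitor, a lower number a stronger inhibitor), compound 2 gives 6850 nM, whereas compound 1 `COc1cc(OC)nc(N2C[C@H]3CN(C(=O)c4ccccc4-c4cccs4)C[C@H]3C2)n1` gives 257 nM in this assay, a gap that lies well beyond the usual scatter. Compound 3 `COc1ccc(C(=O)N2C[C@@H]3CN(c4nc5ccc(Cl)cc5s4)C[C@@H]3C2)c(OC)c1` keeps the whole core of compound 2 and differs from it only in one place: 2,4-dimethoxyphenyl in place of 2,6-dimethoxyphenyl on a carbonyl carbon. Going by the values given here, no measured pair shows this change, so its effect is not known from the data. The two dimethoxyphenyl groups carry the same atoms and differ only in where the methoxy groups sit, so compound 3 is expected to stay close to compound 2, with a step of a 1.0-fold higher number from compound 2 to compound 3 (0.01 log units; within the scatter) that need not reach beyond the scatter. In this assay compound 3 is therefore estimated at 7000 nM, with a plausible range from 2000 nM to 25000 nM.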

Compound 3, inhibition constant: 5300 nM
Estimate against measurement, compound 3: 1.3-fold (0.12 log units) above; low and high end bracket the measured number.
By their numbers in this assay, from the lowest: compound 1; then compounds 3 and 2 (each within the scatter of the next).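

In this assay, swapping the 2,6-dimethoxyphenyl group for the 2,4-dimethoxyphenyl group gives a 1.3-fold lower number from compound 2 to compound 3 (0.11 log units; within the scatter), so this pair does not separate the two arrangements of the methoxy groups. At this position, with the core of compound 2 kept, the change leaves the affinity within the scatter, and neither dimethoxyphenyl group can be ranked above the other. Nothing shown here offers an explanation for this result.

Going by these compounds, what a plain phenyl, a single methoxy group, a fluorine or a pyridine ring would do on this carbonyl carbon remains open. Compound 1 differs from compound 2 and compound 3 in more than one place, so the compounds shown do not tell which of its parts goes with its value.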